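This account rests on a few compounds, and the source may have more. Where it says the series, first, only, none or still open, it means among the compounds named here.

Compound 3 `N=C(S)CCN1N=C(c2ccccc2)CCC1=O` is the compound from which this step starts. Among the compounds with values here, in a functional assay on the whole organism (stomach) for inhibition, with Rattus norvegicus as the target, at a dose of 100 mg/kg by the intraduodenal route (a lower number here means less inhibition, a higher number more inhibition at the dose given (going by the name of the read-out)), compound 3 gives 38.2%, the second highest of the three numbers measured so far. Compound 1 `N=C(S)CCN1N=C(c2cccs2)CCC1=O` gives 58.5% in this assay, and compound 2 `CC1=NN(C(C)CC(=N)S)C(=O)CC1` gives 17.4%. Within the data shown here, only one measured change alters compound 3 in a single place: the step of a number 20.3 percentage points lower from compound 1 to compound 3 (beyond the scatter), which shows that swapping one ring for another on the carbon with a double bond to nitrogen can move the read-out by a clear margin.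

Compound 4 `CC1=NN(CCC(=N)S)C(=O)CC1` differs from compound 3 by methyl in place of phenyl on a carbon with a double bond to nitrogen. Among the measured compounds shown here, compound 2 also carries a methyl on a carbon with a double bond to nitrogen, but it differs from compound 4 in a second place as well, so no single step links the two; its value and that of compound 3 show only that compound 2 sits lower. For the measured compounds named here, the one step measured at this site was a loss when a ring was exchanged for a different ring, and replacing the ring with a methyl is expected to go in the same direction, as a step of a number 16.2 percentage points lower from compound 3 to compound 4 (beyond the scatter). Compound 4 is therefore estimated to give 22% in this assay, within a range from 8% to 38%.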

Compound 4, a percentage reported as inhibition, in the whole organism at one dose (the size of the read-out at that dose, not a potency): 34.8%
The estimate for compound 4 lay 12.8 percentage points below the measured number; low and high end bracket the measured number.
By their numbers in this assay, from the lowest: compound 2; then compounds 4 and 3 (each within the scatter of the next); then compound 1.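

In this assay, the change from phenyl to methyl is a number 3.4 percentage points lower from compound 3 to compound 4 (within the scatter), so at this position on the carbon with a double bond to nitrogen, a six-carbon aromatic ring can give way to a single carbon without a shift beyond the scatter. Thiophen-2-yl now stands apart from both groups, for replacing it with methyl gives a number 23.7 percentage points lower from compound 1 to compound 4 (beyond the scatter), while phenyl and methyl are not separated by this read-out. The pair of compound 2 and compound 4 adds a second site, the saturated chain carbon bound to the amide-type nitrogen in a ring, where hydrogen in place of methyl gives a number 17.4 percentage points higher from compound 2 to compound 4 (beyond the scatter), so the chain can change the read-out as well as the ring substituent.

Going by these compounds, it remains open whether an amine, a carboxylic acid or a furan-2-yl ring at the first site would match thiophen-2-yl or stay with phenyl and methyl, and how a longer chain at the second site would compare with methyl and hydrogen. Nothing measured here gives a reason for any of these differences.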